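The compounds below may be only part of what the source reports. "The series", "measured", "known", "first", "only" and "open" are said of these compounds alone.

Measured compounds: compound 1, `C=CC1=C(C(=O)Nc2ccccc2)C(c2ccc(OC)cc2)OC1`; compound 2, `C=CC1=C(C(=O)NC2CCCCC2)C(c2ccc(OC)cc2)OC1`; compound 3, `C=CC1=C(C(=O)NCc2ccc(Cl)cc2)C(c2ccc(OC)cc2)OC1`.

In a functional assay on HeLa cells (Homo sapiens) for cytotoxicity, read by MTT assay, with a stated time of 24 h (a higher number here means a weaker inhibitor, a lower number a stronger inhibitor), compound 2 gives 24800 nM. Compound 1 reaches only the limit of the assay, > 100000 nM. Compound 3 likewise reaches only the limit, > 100000 nM, so compound 3 stands at the limit of > 100000 nM in this assay, at which 2 of the 3 values shown sit. Compound 4, `C=CC1=C(C(=O)NCCCCC)C(c2ccc(OC)cc2)OC1`, differs from compound 3 by butyl in place of 4-chlorophenyl on a saturated chain carbon bound to an amide-type nitrogen. Among the compounds with values here, the steps that bear on this change are an at least 4.0-fold lower number from compound 1 to compound 2 (0.60 log units; beyond the scatter) and an at least 4.0-fold higher number from compound 2 to compound 3 (0.60 log units; beyond the scatter), the only numeric value belonging to compound 2. Compound 4, carrying a pentyl chain rather than a benzyl group, is expected to move back toward that value, an expected at least 2.0-fold lower number from compound 3 to compound 4 (0.30 log units; that floor lies within the scatter), though a limit remains possible. Compound 4 is therefore estimated at 50000 nM, between 15000 nM and 150000 nM.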

Compound 4, half-maximal inhibitory concentration: > 100000 nM
Compound 4: a limit, no number; the forecaster's own chance of this, stated with the estimate: 40%; middle value at least 2.0-fold (0.30 log units) away from the limit.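

In this assay compound 4 gives > 100000 nM, which is a limit of the assay and not a number. Pentyl in place of cyclohexyl on an amide-type nitrogen gives an at least 4.0-fold higher number from compound 2 to compound 4 (0.60 log units; beyond the scatter), so an open chain does not keep the measurable value, and among the groups shown only cyclohexyl falls short of the limit. The steps to compound 4 from compound 1 and compound 3 cannot be read, and all three compounds sit at one limit: the limit of > 100000 nM in this assay, at which 3 of the 4 values shown sit.

Going by these compounds, it remains open whether cyclopentyl or cycloheptyl on the amide-type nitrogen would also give a measurable value. On these data alone, it also remains open how a cyclohexyl carrying an amine or a carboxylic acid would behave.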